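A few compounds are considered here, and "the series" means these few. Any claim that something is new, unique, unknown or untested is made for them only; others in the source may bear on it.

Measured compounds:
- compound 1 `Cc1coc(-c2ccc3c(c2O)CCCC3(C)C)c1C(=O)O` with 3 uM
- compound 2 `CCOCc1c(C)coc1-c1ccc2c(c1OC)CCCC2(C)C` with 17.7 uM
- compound 3 `Cc1coc(-c2ccc3c(c2O)CCC3)c1C(=O)O` with 38.4 uM

In a functional assay on DU-145 cells (Homo sapiens) for cytotoxicity, read by sulforhodamine B assay, with a stated time of 3 days (on this read-out higher numbers stand for an effect only at larger amounts of compound and lower numbers for an effect already at smaller amounts), compound 2 gives the second highest of the three numbers. Compound 1 gives a lower number, and compound 3 gives a higher number, so compound 2 lies between them; in both directions the gap to compound 2 is beyond the usual scatter of this kind of measurement. Compound 1 and compound 3 also carry a carboxylic acid and a free phenol where compound 2 carries an ethoxymethyl group and a methoxy group, so no single change separates compound 2 from either of them.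

Compound 4 `COc1c(-c2occ(C)c2CO)ccc2c1CCCC2(C)C` has not yet been measured in this assay. Compared with compound 2 the change is small: hydrogen in place of ethyl on an oxygen on a saturated carbon. The oxygen stays, an ethyl group is removed from it, and the rest of the molecule is untouched.

Going by the values given here, because the only measured neighbour here is compound 2 with 17.7 uM, and no measured pair shows the effect of this particular change, the expectation is for a step from compound 2 to compound 4 that stays within the scatter, with no clear direction: a 1.1-fold higher number from compound 2 to compound 4 (0.05 log units; within the scatter). On that basis compound 4 is estimated to give about 20 uM in this assay, with a plausible range from 7 uM to 55 uM.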

Compound 4, concentration for half-maximal effect: 21.7 uM
Compound 4: the middle estimate sits 1.1-fold (0.04 log units) below what was measured, and the stated range covers the measured number.
By their numbers in this assay, from the lowest: compound 1; then compounds 2, 4 and 3 (each within the scatter of the next, the first and the last beyond it).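

In this assay, going by these compounds alone, this is the first pair of compounds that differ in one place, and it gives a 1.2-fold higher number from compound 2 to compound 4 (0.09 log units; within the scatter). Within the data shown here, the change from ethoxymethyl to hydroxymethyl therefore produces no readable difference in this pair, which the earlier compounds could not show, since compound 1 and compound 3 each differ from compound 2 in more than one place. Nothing measured here offers an explanation for why compound 2 and compound 4 read alike.

The compounds shown leave open whether other groups on this oxygen, such as a longer chain like butyl, or an amine in place of the oxygen, would also stay within the scatter, since this single pair covers only hydrogen and ethyl and says nothing about a trend across the position. They also leave open how the same change would read with a free phenol in place of the methoxy group, and whether the carboxylic acid or the free phenol accounts for the lower number of compound 1, at 3 uM, as these two groups appear together in that compound and are never separated.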